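Compound 3: what a piperidine ring might do

A few compounds are considered here, and "the series" means these few. Any claim that something is new, unique, unknown or untested is made for them only; others in the source may bear on it.

Measured in a functional assay on cells (Homo sapiens), read by thymidine incorporation; a lower number here means a stronger inhibitor, a higher number a weaker inhibitor:
Compound 1 `Cc1cc(NCc2cccnc2)n2ncc(Br)c2n1` gives 1800 nM
Compound 2 `CNc1cc(NCc2cccnc2)n2ncc(Br)c2n1` gives 1200 nM

Compound 2 at 1200 nM stands within the usual scatter of compound 1 at 1800 nM, so the two cannot be told apart. The next compound to be tested is compound 3 `Brc1cnn2c(NCc3cccnc3)cc(C3CCNCC3)nc12`, which differs from compound 2 as follows: piperidin-4-yl in place of methylamino on an aromatic carbon. In short, piperidin-4-yl takes the place of methylamino on an aromatic carbon. Going by the values given here, only one measured step bears on this change: a 1.5-fold lower number from compound 1 to compound 2 (0.18 log units; within the scatter). That step stays within the scatter, and neither measured compound carries a ring at this place, so the guide is weak. A modest move to a lower number in this assay is expected, though with real uncertainty about direction. The expected change is a 2.0-fold lower number from compound 2 to compound 3 (0.30 log units; within the scatter). For compound 3 the estimated value is 600 nM, with an expected range from 120 nM to 2500 nM.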

Compound 3, half-maximal inhibitory concentration: 160 nM
For compound 3 the middle estimate is 3.8-fold (0.57 log units) above the measured one, within the range that was stated.
By their numbers in this assay, from the lowest: compound 3; then compounds 2 and 1 (each within the scatter of the next).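

Until now, in this assay, methylamino in place of methyl on this aromatic carbon gave only a step within the scatter, so the two groups could not be told apart. Piperidin-4-yl, a six-membered non-aromatic ring, shows that this position can respond to the group placed on it: it brings a 7.5-fold lower number from compound 2 to compound 3 (0.88 log units; beyond the scatter) and an 11-fold lower number from compound 1 to compound 3 (1.05 log units; beyond the scatter), and both steps lie beyond the scatter. No accompanying measurement explains why this ring has this effect.

The compounds shown leave open whether the whole ring or its nitrogen matters, a question that cyclohexyl, with carbon in place of that nitrogen, could address. They also leave open whether morpholine or an open-chain amine at this position would give a similarly low number.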